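The source may report more compounds than this note shows. Statements on the series, on what has been measured and on what is new or still open speak of the compounds shown alone.

Measured so far:
- compound 1 `Cc1ccc(-n2nc(-c3ccc(C(F)(F)F)cc3O)nc2-c2ccccc2O)cc1` gives 94.1% in a functional assay on PC-12 cells (Rattus norvegicus) for cytotoxicity, read by MTT assay, with stated times of 2 h and 24 h, tested at 5 uM; a lower number here means a weaker effect, a higher number a stronger effect of the compound at the concentration tested
- compound 2 `CCc1ccc(-n2nc(-c3ccc(C(F)(F)F)cc3O)nc2-c2ccccc2O)cc1` gives 95.4% in this assay
- compound 3 `COc1ccc(-n2nc(-c3ccc(C(F)(F)F)cc3O)nc2-c2ccccc2O)cc1` gives 86.6% in this assay

Compound 2 holds the highest of the three numbers, but no separation is real: a number 1.3 percentage points higher from compound 1 to compound 2 (within the scatter), a number 8.8 percentage points lower from compound 2 to compound 3 (within the scatter), and a number 7.5 percentage points lower from compound 1 to compound 3 (within the scatter) are all within the scatter, so the three compounds read as one level in this assay.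

Compound 4 `Oc1cc(C(F)(F)F)ccc1-c1nc(-c2ccccc2O)n(-c2ccccc2C(F)(F)F)n1` differs from compound 2 in one place: 2-(trifluoromethyl)phenyl in place of 4-ethylphenyl on an aromatic nitrogen. Going by the values given here, none of the measured steps covers this kind of change. The three steps that exist only exchange the group on the phenyl ring bound to the aromatic nitrogen (methyl, ethyl, methoxy), and each of them stayed within the scatter. The step to compound 4 replaces that whole ring, which is a larger change than anything measured, so the comparison rests on the shared core alone. On that basis, and with all three values at the high end of the read-out, the expected step is a number 6.4 percentage points lower from compound 2 to compound 4 (within the scatter), that is, none beyond the scatter, with the range widened for the untested nature of the change. Compound 4 is estimated at 89% in this assay, between 72% and 100%.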

Compound 4, a percentage reported as activity, at one concentration (the size of the read-out at that concentration, not a potency): 80%
Estimate against measurement, compound 4: 9 percentage points above; the measured number falls inside the stated range.
By their numbers in this assay, from the lowest: compounds 4, 3, 1 and 2 (each within the scatter of the next, the first and the last beyond it).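

Exchanging the whole ring on the aromatic nitrogen gives the first separation in this series in this assay: there is a number 15.4 percentage points lower from compound 2 to compound 4 (beyond the scatter) and a number 14.1 percentage points lower from compound 1 to compound 4 (beyond the scatter), both modest. Compound 3 goes against a clean separation, with a number 6.6 percentage points lower from compound 3 to compound 4 (within the scatter), so 2-(trifluoromethyl)phenyl stands apart from 4-ethylphenyl and 4-methylphenyl but not from 4-methoxyphenyl, and the position responds to this change only to a modest degree. Nothing available bears on what lies behind the lower number for compound 4.

On these data alone, it remains open whether that lower number goes with the trifluoromethyl group as such or with the replacement of the ring as a whole. Also open, as far as these compounds go, is how a phenyl ring on the same nitrogen bearing an amine, a carboxylic acid or a chain longer than ethyl would read in this assay.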